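From methoxy to hydroxy on compound 3

This account rests on a few compounds, and the source may have more. Where it says the series, first, only, none or still open, it means among the compounds named here.

In a functional assay on DLD-1 cells (Homo sapiens) for cytotoxicity, read by resazurin assay, with a stated time of 48 h (on this read-out higher numbers stand for an effect only at larger amounts of compound and lower numbers for an effect already at smaller amounts), compound 3 `COc1c(Br)cccc1C(=O)Nc1ccc(Sc2nc3ccccc3s2)cc1` gives 40000 nM. Two other compounds offer a comparison: compound 1 `O=S(=O)(Nc1ccc(-c2nc3cc(NS(=O)(=O)c4ccc(Cl)s4)ccc3o2)cc1)c1ccc(Cl)c(C(F)(F)F)c1` gives 22000 nM, and compound 2 `O=C(Nc1ccc(Sc2nc3ccccc3s2)c(Cl)c1)c1cccc(Br)c1O` gives 22000 nM. The number for compound 3 lies within the usual scatter of both, so these measurements do not separate it from either one.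

Compound 4 `O=C(Nc1ccc(Sc2nc3ccccc3s2)cc1)c1cccc(Br)c1O` differs from compound 3 by a single change, hydrogen in place of methyl on an oxygen on an aromatic ring, or methoxy to hydroxy. For the measured compounds named here, no pair of measured compounds shows the effect of this change directly. Going by the values given here, the only clue is compound 2, which also carries a hydroxy group and gives 22000 nM, although it is not a clean comparison. A modest shift towards a lower number in this assay is therefore expected, possibly no larger than the scatter. The expected result is a 1.8-fold lower number from compound 3 to compound 4 (0.26 log units; within the scatter). For compound 4, the estimate is 22000 nM, with an expected range of 8000 nM to 50000 nM.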

Compound 4, half-maximal effective concentration: 12000 nM
Beside the measured number, compound 4's estimate is 1.8-fold (0.26 log units) above it, within the range that was stated.
By their numbers in this assay, from the lowest: compounds 4, 1, 2 and 3 (each within the scatter of the next, the first and the last beyond it).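

In this assay, putting hydrogen in place of methyl on the oxygen gives a 3.3-fold lower number from compound 3 to compound 4 (0.52 log units; beyond the scatter). For the compounds shown here, this is the first direct view of the change from methoxy to hydroxy, and the step is modest but beyond the scatter, so at this position the methyl cannot be swapped for hydrogen without a measurable shift. Hydrogen in place of chloro on an aromatic carbon gives a 1.8-fold lower number from compound 2 to compound 4 (0.26 log units; within the scatter), which is within the scatter, so these measurements separate compound 2 from compound 4 no more than repeated tests would, and nothing measured here accounts for either step.

From the compounds shown here alone, whether an amine or a carboxylic acid in place of the hydroxy would keep, lose or extend the shift remains open. Only compound 3 and compound 4 show the methoxy to hydroxy change, so whether it holds on a chloro-bearing compound such as compound 2 is also unknown.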